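A few compounds are considered here, and "the series" means these few. Any claim that something is new, unique, unknown or untested is made for them only; others in the source may bear on it.

Compound 2, `Cc1ccc(S(=O)(=O)N2CCCCC2C)cc1C#Cc1cc(Cl)ccc1OCC(=O)O`, is tested in a functional assay on cells for antagonist activity at prostaglandin D2 receptor 2 (Homo sapiens), read by flow cytometry, with a stated time of 10 min (on this read-out lower numbers stand for stronger inhibition and higher numbers for weaker inhibition), and gives 310 nM, the highest number of the two compounds measured there. Within the data shown here, its only neighbour, compound 1, `Cc1ccc(S(=O)(=O)N(C)C(C)C)cc1C#Cc1cc(Cl)ccc1OCC(=O)O`, gives 140 nM in this assay. Among the measured compounds shown here, the one measured step that speaks to the change in hand is a 2.2-fold higher number from compound 1 to compound 2 (0.35 log units; beyond the scatter), a modest rise in the number when the acyclic isopropyl(methyl)amino on the sulfonyl sulfur is closed into the ring of 2-methylpiperidin-1-yl. Compound 3, `Cc1ccc(S(=O)(=O)N(C)C)cc1C#Cc1cc(Cl)ccc1OCC(=O)O`, carries dimethylamino in place of 2-methylpiperidin-1-yl on a sulfonyl sulfur, so the ring is opened again and the amine shrinks to dimethylamino. With a single acyclic-to-cyclic step to go on, compound 3 is expected to move back toward compound 1 by roughly the size of that step, meaning a 2.1-fold lower number from compound 2 to compound 3 (0.32 log units; beyond the scatter). Compound 3 is therefore estimated at 150 nM in this assay, with a range from 60 nM to 400 nM.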

Compound 3, half-maximal inhibitory concentration: 77 nM
Compound 3: the middle estimate sits 1.9-fold (0.29 log units) above what was measured; measured number inside the range.
By their numbers in this assay, from the lowest: compounds 3 and 1 (each within the scatter of the next); then compound 2.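

On the sulfonyl sulfur, opening the ring to dimethylamino gives a 4.0-fold lower number from compound 2 to compound 3 (0.60 log units; beyond the scatter) in this assay, so with this result 2-methylpiperidin-1-yl stands apart from both acyclic amines, not from isopropyl(methyl)amino alone. The two acyclic amines do not separate from each other: a 1.8-fold lower number from compound 1 to compound 3 (0.26 log units; within the scatter), so methyl in place of isopropyl on the sulfonamide nitrogen leaves no readable change. Nothing available explains why the ring-bearing compound 2 reads differently from the two open amines.

The compounds shown leave open whether the ring itself or the methyl on it goes with the higher number of compound 2, a question that plain piperidin-1-yl would address. They also leave open how a smaller ring such as pyrrolidin-1-yl, or a ring with a second hetero atom such as morpholin-4-yl, would read on the same sulfur.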